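From compound 3 to compound 4 at the assay limit

The source may hold more compounds than are shown below. What is called first, only, known or untested is meant among the compounds shown, and "the series" means these compounds.

Measured so far in a functional assay on PC-3 cells (Homo sapiens) for inhibition, read by MTT assay, with a stated time of 48 h; a lower number here means a stronger inhibitor, a higher number a weaker inhibitor
- Compound 1 `COc1ccc(-n2c(SC)nnc2-c2cc(OC)c(OC)c(OC)c2)cc1` gives > 60000 nM
- Compound 2 `COc1ccc(C(=O)CSc2nnc(-c3cc(OC)c(OC)c(OC)c3)n2-c2ccc(OC)cc2)cc1` gives > 60000 nM
- Compound 3 `COc1cc(-c2nnc(SC)n2-c2ccc(N(C)C)cc2)cc(OC)c1OC` gives > 60000 nM

Compound 3 sits at > 60000 nM as a limit, not a number. The whole record so far is the limit of > 60000 nM in this assay, at which 3 of the 3 values shown sit, and so gives no order among the three compounds.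

The next compound, compound 4 `COc1cc(-c2nnc(SCc3ccc(C)cc3)n2-c2ccc(N(C)C)cc2)cc(OC)c1OC`, keeps the core and the dimethylamino group of compound 3 and changes one place: 4-methylphenyl in place of hydrogen on a saturated chain carbon bound to a sulfur, which turns methylsulfanyl into (4-methylbenzyl)sulfanyl.

Within the data shown here, two measured steps bear on this. The closer one is a step that the two limits leave unreadable from compound 1 to compound 2, made at the same kind of place, a saturated chain carbon bound to a sulfur. The other is a step that the two limits leave unreadable from compound 1 to compound 3, with dimethylamino in place of methoxy on an aromatic carbon. Neither has a readable size, so neither offers a size to carry over. Compound 2 ended at > 60000 nM as a limit, so the one earlier addition at this place produced no number.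

The expected change is an at least 1.3-fold lower number from compound 3 to compound 4 (0.12 log units; that floor lies within the scatter), toward stronger inhibition if it can be read at all. Compound 4 is expected near 45000 nM, with an estimated range from 15000 nM to 90000 nM, and it may well report only a limit again.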

Compound 4, half-maximal inhibitory concentration: 37300 nM
The estimate for compound 4 lay 1.2-fold (0.08 log units) above the measured number; low and high end bracket the measured number.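

In this assay, the addition of 4-methylphenyl on a saturated chain carbon bound to a sulfur gives an at least 1.6-fold lower number from compound 3 to compound 4 (0.20 log units; that floor lies within the scatter), so this place can hold a group that brings a readable number, although the floor of that step alone does not establish a real gain. The other steps cannot be read, including the one that added (4-methoxyphenyl)carbonyl at the same kind of place, so they gave no sign of how this position responds to change. Compound 4 is the only one of the four compounds with a number rather than a limit: the limit of > 60000 nM in this assay, at which 3 of the 4 values shown sit.

As far as these compounds go, the size of the step remains open, since one end of it is a limit, and it is also unknown whether 4-methylphenyl would bring a number with methoxy in place of dimethylamino on the aromatic carbon. The compounds shown also leave open what an unsubstituted phenyl, a carboxylic acid or a longer chain would give on this saturated chain carbon bound to a sulfur.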